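This account rests on a few compounds, and the source may have more. Where it says the series, first, only, none or still open, it means among the compounds named here.

In a functional assay on KB cells (Homo sapiens) for antiproliferative activity, read by MTT assay, with a stated time of 72 h (a lower number here means a stronger inhibitor, a higher number a weaker inhibitor), compound 3 (`CCOC(=O)c1cc(-c2ccc(OC)cc2)c(-c2cc(OC)c(OC)c(OC)c2)s1`) gives 10200 nM and lies within the scatter of compound 2 (`COc1ccc(-c2sc(C(=O)O)cc2-c2cc(OC)c(OC)c(OC)c2)cc1O`) at 11200 nM and of compound 1 (`CCOC(=O)c1cc(-c2cc(OC)c(OC)c(OC)c2)c(-c2ccc(OC)c([N+](=O)[O-])c2)s1`) at 15800 nM with no real separation among the three. Compound 4 (`CCOC(=O)c1cc(-c2ccc(OC)c([N+](=O)[O-])c2)c(-c2cc(OC)c(OC)c(OC)c2)s1`) differs from compound 3 by a single change (nitro in place of hydrogen on an aromatic carbon) that reads nitro in place of hydrogen on an aromatic carbon, ortho to a methoxy group, taking 4-methoxyphenyl to 4-methoxy-3-nitrophenyl. Going by the values given here, no measured pair isolates this change, so the evidence for its size is indirect. Compound 1 already carries the 4-methoxy-3-nitrophenyl group and stands at 15800 nM in the same band as compound 3, so no step beyond the scatter is expected in this assay and no firm direction can be assigned. The expected step of a 1.2-fold higher number from compound 3 to compound 4 (0.07 log units; within the scatter) is estimated to lie within the scatter. For compound 4 the expected value is 12000 nM with an estimated range of 5000 nM to 30000 nM as the working bracket.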

Compound 4, half-maximal inhibitory concentration: 24000 nM
For compound 4 the middle estimate is 2.0-fold (0.30 log units) below the measured one, within the range that was stated.
By their numbers in this assay, from the lowest: compounds 3, 2, 1 and 4 (each within the scatter of the next, the first and the last beyond it).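

In this assay, going by these compounds alone, nitro in place of hydrogen on the aromatic carbon ortho to a methoxy group gives the first step that can be read: a 2.4-fold higher number from compound 3 to compound 4 (0.37 log units; beyond the scatter), a modest weakening beyond the scatter. This position is therefore not indifferent to substitution, at least for this one pair, and the nitro group costs activity here rather than adding to it. Nothing at hand gives a measured property that would account for the step.

From the compounds shown here alone, whether an amine or a fluorine atom on the same carbon would also weaken compound 3 remains open, so the step cannot yet be assigned to the nitro group itself rather than to any substituent there. Also open, going by these compounds, is whether the same change carries over when the ethyl ester gives way to an amide.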